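The source may hold more compounds than are shown below. What is called first, only, known or untested is meant among the compounds shown, and "the series" means these compounds.

Compound 3 `CC(C)c1n[nH]c2c(NCc3ccc(-c4ccccn4)cc3)nc(SCCCN(C)C)nc12` gives 105 nM in a functional assay on HT cells (Homo sapiens) for antiproliferative activity, read by fluorescence, with a stated time of 72 h (on this read-out higher numbers stand for weaker inhibition of growth and lower numbers for stronger inhibition of growth), and holds the second highest of the three numbers: compound 1 `CC(C)c1n[nH]c2c(NCc3ccc(-c4ccccn4)cc3)nc(SCC(O)CO)nc12` gives 21 nM, while compound 2 `CC(C)c1n[nH]c2c(NCc3ccc(-c4ccccn4)cc3)nc(SCC(O)C(F)(F)F)nc12` gives 690 nM. Compound 4 `CC(C)c1n[nH]c2c(NCc3ccc(-c4ccccn4)cc3)nc(S)nc12` differs from compound 3 by hydrogen in place of 3-(dimethylamino)propyl on a sulfur. Every measured step changes the group on that same sulfur: a 33-fold higher number from compound 1 to compound 2 (1.52 log units; beyond the scatter), a 5.0-fold higher number from compound 1 to compound 3 (0.70 log units; beyond the scatter) and a 6.6-fold lower number from compound 2 to compound 3 (0.82 log units; beyond the scatter). None of them removes the chain altogether, so the bearing is indirect. Each of those changes moved the number beyond the scatter, and a shift beyond the scatter is likewise expected here. With no measured case of hydrogen on the sulfur, a weaker result is the working expectation, namely a 4.8-fold higher number from compound 3 to compound 4 (0.68 log units; beyond the scatter). Compound 4 is therefore estimated at 500 nM, within a range of 80 nM to 3000 nM.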

Compound 4, concentration for 50% growth inhibition: 2760 nM
Beside the measured number, compound 4's estimate is 5.5-fold (0.74 log units) below it; measured number inside the range.
By their numbers in this assay, from the lowest: compound 1; then compound 3; then compound 2; then compound 4.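

Hydrogen on the sulfur gives the weakest growth inhibition of the four, with a 26-fold higher number from compound 3 to compound 4 (1.42 log units; beyond the scatter) and a 130-fold higher number from compound 1 to compound 4 (2.12 log units; beyond the scatter), and even the trifluorinated chain keeps an advantage, with a 4.0-fold higher number from compound 2 to compound 4 (0.60 log units; beyond the scatter). Each of the three chains, 2,3-dihydroxypropyl, 3,3,3-trifluoro-2-hydroxypropyl and 3-(dimethylamino)propyl, therefore gives a lower number than the bare sulfanyl compound, so substitution on this sulfur matters as well as the choice of chain. Nothing available explains these shifts. Still open, as far as these compounds go, is whether a single methyl on the sulfur recovers any of this loss, and how a carboxylic acid in place of the dimethylamino group would read.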